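Chloroacetamide to glycinamide on a uracil amide

The compounds below may be only part of what the source reports. "The series", "measured", "known", "first", "only" and "open" are said of these compounds alone.

Measured so far:
compound 2 `O=C(CCl)Nc1c[nH]c(=O)[nH]c1=O`: 12000 nM
compound 1 `Cc1ccc(S(=O)(=O)Nc2cc[nH]c(=O)n2)cc1`: > 100000 nM, a limit of the assay
compound 3 `Cc1cc(=O)[nH]c(=O)n1COC(CO)CO`: > 100000 nM, a limit of the assay

In a functional assay on SW-620 cells (Homo sapiens) for inhibition, read by MTT assay, with a stated time of 72 h (a higher number here means a weaker inhibitor, a lower number a stronger inhibitor), only compound 2 gives a number, 12000 nM. Compound 1 returns only a limit. Compound 3 returns only a limit as well. So the set rests on (the limit of > 100000 nM in this assay, at which 2 of the 3 values shown sit), and compound 2 stands as the one compound with a measured value, with nothing measured on either side of it to compare against.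

Compound 4 `NCC(=O)Nc1c[nH]c(=O)[nH]c1=O` is the next compound, and it differs from compound 2 in one place: amino in place of chloro on a saturated chain carbon bound to a carbonyl carbon. For the measured compounds named here, no step between two measured compounds of this set touches this change, so there is no measured guide to its size or direction. The expectation is that this change takes the value of compound 4 away from that of compound 2 toward weaker inhibition, estimated at a 4.2-fold higher number from compound 2 to compound 4 (0.62 log units; beyond the scatter), a step beyond the usual scatter. Compound 4 is therefore expected to give about 50000 nM in this assay, within 12000 nM to 200000 nM, with a fair chance that only a limit is reported.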

Compound 4, half-maximal inhibitory concentration: > 100000 nM
Compound 4: no number, only a limit; the forecaster's own chance of this, stated with the estimate: 45%; middle value at least 2.0-fold (0.30 log units) away from the limit.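

The step of an at least 8.3-fold higher number from compound 2 to compound 4 (0.92 log units; beyond the scatter) gives the set its first measured comparison in this assay, and it shows that this place on the chain is not indifferent to what it carries. Amino in place of chloro is enough to remove the only measured value, leaving compound 2 as the sole compound with a number, and the step's true size stays unknown, as compound 4 returns only a limit. The set now leans even further on that limit: the limit of > 100000 nM in this assay, at which 3 of the 4 values shown sit.

From the compounds shown here alone, what a bromo or a hydroxyl group would give at this same place remains open, as does the effect of a longer chain ending in chloro. One step also cannot tell whether the value of compound 2 depends on chloro itself or whether amino alone is poorly tolerated here.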